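The compounds below may be only part of what the source reports. "The series", "measured", "known", "first", "only" and "open" are said of these compounds alone.

Measured in a functional assay on A549 cells (Homo sapiens) for cytotoxicity, read by MTT assay, with a stated time of 72 h; on this read-out higher numbers stand for weaker inhibition and lower numbers for stronger inhibition:
compound 1 `COc1cc2c(Oc3ccc(NC(=O)c4cn(-c5ccc(F)c(F)c5)nn4)cc3F)ccnc2cc1OCCCN1CCC(C)CC1` gives 1460 nM;
compound 2 `COc1cc2c(Oc3ccc(NC(=O)c4cn(-c5ccccc5C)nn4)cc3F)ccnc2cc1OCCCN1CCN(C)CC1` gives 3100 nM.

Compound 2 stands highest of the two numbers; compound 1 is its nearest neighbour, with a number that lies below it by more than the usual scatter. Compound 3 `COc1cc2c(Oc3ccc(NC(=O)c4cn(-c5ccc(F)c(F)c5)nn4)cc3F)ccnc2cc1OCCCN1CCN(C)CC1` has not yet been measured in this assay. It differs from compound 2 in one place: 3,4-difluorophenyl in place of 2-methylphenyl on an aromatic nitrogen. Within the data shown here, no measured pair shows this change on its own, so its size cannot be read from a direct comparison. Compound 1 carries the same 3,4-difluorophenyl group on an aromatic nitrogen, though it differs from compound 3 elsewhere, and in this assay compound 1 gives 1460 nM. On that basis compound 3 is expected to move toward a lower number, a step of a 1.7-fold lower number from compound 2 to compound 3 (0.24 log units; within the scatter) of modest size. The estimate for compound 3 is 1800 nM, with a range from 700 nM to 4500 nM.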

Compound 3, half-maximal inhibitory concentration: 200 nM
Beside the measured number, compound 3's estimate is 9.0-fold (0.95 log units) above it; the whole stated range lies above it.
By their numbers in this assay, from the lowest: compound 3; then compound 1; then compound 2.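

With the 4-methylpiperazin-1-yl group held constant, the group on the aromatic nitrogen of the five-membered ring turns out to matter greatly in this assay: 3,4-difluorophenyl in place of 2-methylphenyl gives a 16-fold lower number from compound 2 to compound 3 (1.19 log units; beyond the scatter). The other end of the molecule also counts: with 3,4-difluorophenyl kept, 4-methylpiperazin-1-yl in place of 4-methylpiperidin-1-yl gives a 7.3-fold lower number from compound 1 to compound 3 (0.86 log units; beyond the scatter), so each of the two places moves the number beyond the scatter on its own. No information at hand accounts for either step.

As far as these compounds go, it remains open whether an unsubstituted phenyl or a 4-fluorophenyl on that aromatic nitrogen would give a comparable step. From the compounds shown here alone, it is equally open whether a morpholin-4-yl group at the end of the chain would match 4-methylpiperazin-1-yl.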